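The source may report more compounds than this note shows. Statements on the series, on what has been measured and on what is new or still open speak of the compounds shown alone.

In an ADME assay on HepG2 cells (Homo sapiens) for cytotoxicity, read by trypan blue exclusion, with a stated time of 48 h, in the presence of a further agent that is not named here (on this read-out lower numbers stand for higher toxicity in this test and higher numbers for lower toxicity in this test), compound 2, whose structure is `COc1ccc(NC(=O)COc2cc(C)nc3ccc(OC)cc23)cc1`, gives > 142000 nM, and this is a limit of the test rather than a measured number; it sits at the limit of > 142000 nM in this assay, at which 1 of the 3 values shown sits. Compound 1, with structure `c1ccc(Cn2cnc3c(-c4ccco4)nccc32)cc1`, gives > 25000 nM in this assay, again a limit. Compound 3, with structure `COc1cc(NC(=O)COc2cc(C)nc3ccc(OC)cc23)cc(OC)c1`, gives > 131000 nM in this assay, also a limit. So compound 2 stands among three entries none of which reached a measurable point; every value in this assay so far is a limit.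

Compound 4, with structure `COc1ccc2nc(C)cc(OCC(=O)Nc3ccc(C)cc3)c2c1`, is not yet measured. The change from compound 2 is methyl in place of methoxy on an aromatic carbon. Going by the values given here, no measured pair of compounds shows what such a change does here, so the expected step from compound 2 to compound 4 is none beyond the scatter, and most likely another limit. Compound 4 is therefore estimated to give 150000 nM in this assay, with a range from 50000 nM to 450000 nM. This estimate means a step that the limit leaves unreadable from compound 2 to compound 4, which is expected to stay within the scatter.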

Compound 4, half-maximal cytotoxic concentration: > 149000 nM
Compound 4 was reported as a limit (the forecaster's own chance of this, stated with the estimate: 85%); the middle value does not contradict the limit.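

Compound 2 and compound 4 both stand as limits in this assay, and the step between them, methyl in place of methoxy, cannot be read. The compounds shown leave open whether methoxy and methyl differ at all, since none reaches a measured value.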